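Swapping one chain carbon for oxygen in compound 3

The source may report more compounds than this note shows. Statements on the series, on what has been measured and on what is new or still open speak of the compounds shown alone.

compound 1 `O=C(O)CCNC(=O)c1ccc2c(c1)C(=O)N(CCC1CCNCC1)C2`: 27 nM
compound 2 `CCCCS(=O)(=O)N[C@@H](CNC(=O)c1ccc2c(c1)C(=O)N(CCC1CCNCC1)C2)C(=O)O`: 14 nM; 9 nM (2 entries)
compound 3 `CCCCCS(=O)(=O)N[C@@H](CNC(=O)c1ccc2c(c1)C(=O)N(CCC1CCNCC1)C2)C(=O)O`: 9 nM

In a functional assay for inhibition, with Homo sapiens as the target (on this read-out lower numbers stand for stronger inhibition and higher numbers for weaker inhibition), compound 3 gives 9 nM. Adding (pentylsulfonyl)amino is a modest step, a 3.0-fold lower number from compound 1 to compound 3 (0.48 log units; beyond the scatter). Compound 4 `CCOCCS(=O)(=O)N[C@@H](CNC(=O)c1ccc2c(c1)C(=O)N(CCC1CCNCC1)C2)C(=O)O` changes only the end of the sulfonyl chain: ethoxy in place of propyl on a saturated chain carbon, two bonds along the chain from a sulfonyl sulfur. The added group as a whole says little about so small a swap. Compound 2 is the closer guide, since it differs from compound 3 only in chain length. Its record, (the several entries of compound 2 in this assay, 14 nM; 9 nM (2 entries)), overlaps the value of compound 3, so that chain shows no clear sensitivity here. In this assay the expected result is a 1.3-fold higher number from compound 3 to compound 4 (0.12 log units; within the scatter), which means no step beyond the scatter. The estimated value for compound 4 is 12 nM, with an expected range of 5 nM to 28 nM.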

Compound 4, half-maximal inhibitory concentration: 8 nM
The estimate for compound 4 lay 1.5-fold (0.18 log units) above the measured number; the range from low to high includes it.
By their numbers in this assay, from the lowest: compounds 4 and 3 (each within the scatter of the next); then compound 1.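

In this assay, among the compounds shown here, the earlier compounds varied the sulfonyl chain only in length, and compound 2 overlapped compound 3: the several entries of compound 2 in this assay, 14 nM; 9 nM (2 entries). Compound 4 shows that the chain also accepts a change of atom type, since ethoxy in place of propyl, which adds a hydrogen-bond acceptor, gives a 1.1-fold lower number from compound 3 to compound 4 (0.05 log units; within the scatter). The gain over the parent acid also survives the swap, with a 3.4-fold lower number from compound 1 to compound 4 (0.53 log units; beyond the scatter). The compounds shown leave open whether an amine or a hydroxyl at the end of this chain, or a much longer chain, would be accepted as readily.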